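Ester alkyl variation in the shared core series

The compounds below may be only part of what the source reports. "The series", "measured", "known", "first", "only" and "open" are said of these compounds alone.

Measured compounds:
- compound 1 `CC1=C(C(=O)OC(C)(C)C)C(c2cc([N+](=O)[O-])ccc2O)C2=C(CCC(C)(C)C2=O)N1`: < 30%
- compound 2 `CCOC(=O)C1=C(C)NC2=C(C(=O)C(C)(C)CC2)C1c1cc([N+](=O)[O-])ccc1O`: 70%
- compound 3 `CC1=C(C(=O)OCC(C)C)C(c2cc([N+](=O)[O-])ccc2O)C2=C(CCC(C)(C)C2=O)N1`: 70%

In an assay for inhibition of Voltage-dependent L-type calcium channel subunit alpha-1C (Rattus norvegicus), read by patch clamp, tested at 10 uM (a lower number here means less inhibition, a higher number more inhibition at the concentration tested (going by the name of the read-out)), compound 1 gives only a limit of the assay, < 30% (the limit of < 30% in this assay, at which 1 of the 3 values shown sits). Compound 2 gives 70% in this assay. Compound 3 gives 70% in this assay and so stands level with compound 2 at the digits shown; the two values are within the scatter of each other, and no order between them can be read.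

The step from compound 1 to compound 2, ethyl in place of tert-butyl on an oxygen next to a carbonyl group, reads a number at least 40 percentage points higher from compound 1 to compound 2 (beyond the scatter). The step from compound 1 to compound 3 reads a number at least 40 percentage points higher from compound 1 to compound 3 (beyond the scatter). The step from compound 2 to compound 3 reads no change at the digits printed from compound 2 to compound 3 (within the scatter).

Compound 4 `COC(=O)C1=C(C)NC2=C(C(=O)C(C)(C)CC2)C1c1cc([N+](=O)[O-])ccc1O` is not yet measured. It differs from compound 3 as follows: hydrogen in place of isopropyl on a saturated chain carbon bound to an oxygen next to a carbonyl group.

The step from compound 2 to compound 3, which also changes only the alkyl on the saturated chain carbon bound to an oxygen next to a carbonyl group, was within the scatter. The step to compound 4 is therefore expected to be a number 5 percentage points lower from compound 3 to compound 4 (within the scatter), no change beyond the scatter. Compound 4 is estimated at 65% in this assay, within a range from 45% to 85%.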

Compound 4, a percentage reported as inhibition, at one concentration (the size of the read-out at that concentration, not a potency): < 30%
Compound 4: only a limit was reported; the forecaster's own chance of this, stated with the estimate: 10%; at least 35 percentage points between middle value and limit.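

The isobutoxycarbonyl to methoxycarbonyl change reads a number at least 40 percentage points lower from compound 3 to compound 4 (beyond the scatter), and the shorter change from ethyl to methyl on the same oxygen reads a number at least 40 percentage points lower from compound 2 to compound 4 (beyond the scatter). In this assay, among the compounds shown here, the loss at this ester is therefore no longer tied to tert-butyl alone: ethyl in compound 2 and isobutyl in compound 3 keep the inhibition, while methyl in compound 4 and tert-butyl in compound 1 do not, a two-sided picture that the earlier compounds could not show. Compound 4 gives < 30%, which is a limit of the assay, so the step between compound 1 and compound 4 cannot be read and the two ends of the alkyl set cannot be ordered: the limit of < 30% in this assay, at which 2 of the 4 values shown sit.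

The compounds shown leave open how n-propyl, isopropyl or a longer chain such as n-hexyl would read on this oxygen, and so where the readings change along the alkyl set. They also leave open whether a benzyl ester, an amide or a carboxylic acid at this place would read with the ethyl and isobutyl esters or with the methyl and tert-butyl esters.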